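Swapping a Fluorophenyl for a Dimethylphenyl on a Piperazine

A few compounds are considered here, and "the series" means these few. Any claim that something is new, unique, unknown or untested is made for them only; others in the source may bear on it.

Measured so far in an assay on HEK293 cells for inhibition of Voltage-dependent T-type calcium channel subunit alpha-1G (Homo sapiens), read by fluorescence, tested at 10 uM; on this read-out lower numbers stand for less inhibition and higher numbers for more inhibition at the one concentration tested (going by the name of the read-out):
compound 1 `CCCc1nc(-c2ccccc2)c(CNCCCN2CCN(c3ccc(F)cc3)CC2)o1` gives 62.5%
compound 2 `CCCc1nc(-c2ccccc2)c(CNCCN2CCN(c3cccc(OC)c3)CC2)o1` gives 40.2%

Compound 1 stands highest of the two numbers; the nearest number, that of compound 2, lies lower by a gap beyond the usual scatter. Compound 2 differs from compound 1 in more than one place, so no single change can be read from that gap.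

Compound 3 `CCCc1nc(-c2ccccc2)c(CNCCCN2CCN(c3ccc(C)c(C)c3)CC2)o1` has not yet been measured in this assay. It differs from compound 1 in one place: 3,4-dimethylphenyl in place of 4-fluorophenyl on an amine nitrogen in a ring. Among the measured compounds shown here, no pair of measured compounds shows this change by itself, so the data give no step to go by. With nothing pointing either way, the step of a number 0.5 percentage points lower from compound 1 to compound 3 (within the scatter) in this assay is expected to stay within the scatter, in no clear direction. Compound 3 is therefore estimated at 62% in this assay, with a range from 42% to 82%.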

Compound 3, a percentage reported as inhibition, at one concentration (the size of the read-out at that concentration, not a potency): 54.6%
Estimate against measurement, compound 3: 7.4 percentage points above, and the stated range covers the measured number.
By their numbers in this assay, from the lowest: compound 2; then compounds 3 and 1 (each within the scatter of the next).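

In this assay, among the compounds shown here, putting 3,4-dimethylphenyl in place of 4-fluorophenyl on the amine nitrogen of the ring gives a number 7.9 percentage points lower from compound 1 to compound 3 (within the scatter), the first step here that changes a single place. At this position, then, the swap of one carbon-only aromatic ring for another, with fluorine exchanged for methyl groups, produces no change that this read-out can tell apart from ordinary repeat variation. No measurement here explains the outcome or says what either group contributes.

As far as these compounds go, it remains open whether a quite different group on this nitrogen, such as a pyridine ring, a benzyl group or a phenyl ring bearing a carboxylic acid, would move the number beyond the scatter. Whether the same swap would read alike on the linker of compound 2 is also unknown.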